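Alanine to valine in a mercaptopropanoyl amino acid series

This account rests on a few compounds, and the source may have more. Where it says the series, first, only, none or still open, it means among the compounds named here.

Measured compounds in a functional assay on KB 3-1 cells (Homo sapiens) for cytotoxicity, read by MTT assay, with a stated time of 72 h; a lower number here means a stronger inhibitor, a higher number a weaker inhibitor:
compound 1, `COC(=O)CNC(=O)C(C)S`, gives 510000 nM.
compound 2, `CSC(C)C(=O)NCC(=O)O`, gives > 20000000 nM, which is a limit of the assay and not a number.
compound 3, `CC(S)C(=O)N[C@@H](C)C(=O)O`, gives 18300000 nM.

Of the two numbers recorded in this assay, compound 3 stands highest; compound 1 is the nearer of the others, with its value set well apart, beyond the scatter. Compound 2 is known only through a limit, (the limit of > 20000000 nM in this assay, at which 1 of the 3 values shown sits), and its value is therefore treated as such here rather than as a number.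

Compound 4, `CC(S)C(=O)N[C@H](C(=O)O)C(C)C`, is not yet measured. It differs from compound 3 in one place: isopropyl in place of methyl on a saturated chain carbon bound to an amide-type nitrogen and a carbonyl carbon. Among the measured compounds shown here, no pair among the measured compounds differs in this way, so no measured step tells how such a change plays out in this assay.

Given how weak compound 3 already is at 18300000 nM, the step from compound 3 to compound 4 is expected to be small, a 1.4-fold higher number from compound 3 to compound 4 (0.14 log units; within the scatter), with no change beyond the scatter or a slight drift toward weaker inhibition. For compound 4 the expected value in this assay is 25000000 nM, within 8000000 nM to 80000000 nM, with a real chance that only a limit is reported.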

Compound 4, half-maximal inhibitory concentration: 12800000 nM
Estimate against measurement, compound 4: 2.0-fold (0.29 log units) above, and the stated range covers the measured number.
By their numbers in this assay, from the lowest: compound 1; then compounds 4 and 3 (each within the scatter of the next). At a limit, above all of these: compound 2.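

In this assay, the saturated chain carbon bound to an amide-type nitrogen and a carbonyl carbon now has its first measured step: isopropyl in place of methyl gives a 1.4-fold lower number from compound 3 to compound 4 (0.16 log units; within the scatter) and leaves the read-out within the usual scatter. The entering group counts 3 heavy atoms against 1 for the group that leaves, yet this pair shows no measurable change in either direction, and both compounds remain weak inhibitors in this assay. This is one pair at one place, and nothing shown gives a cause for the flat result.

On these data alone, whether a longer chain, a phenyl ring or an amine at this same place would leave the number equally unmoved stays open, as does whether the methyl ester seen in compound 1 would carry any change at this place in the same way. Compound 2 is known only through a limit of the assay, and it offers no step to set beside this one: the limit of > 20000000 nM in this assay, at which 1 of the 4 values shown sits.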